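Swapping the Aryl Sulfonate Ester: Methyl Out, Hydroxyl In

The source may hold more compounds than are shown below. What is called first, only, known or untested is meant among the compounds shown, and "the series" means these compounds.

Compound 1 `Cc1ccccc1OS(=O)(=O)c1ccc(NC(=O)NCCCCl)cc1` gives 27000 nM in a functional assay on MCF7 cells (Homo sapiens) for cytotoxicity, read by sulforhodamine B assay, with a stated time of 48 h; a higher number here means a weaker inhibitor, a lower number a stronger inhibitor.
Compound 2 `CCNC(=O)Nc1ccc(S(=O)(=O)Oc2ccccc2C)cc1` gives 4500 nM in this assay.
Compound 3 `CCCc1ccccc1OS(=O)(=O)c1ccc(NC(=O)NCC)cc1` gives 1300 nM in this assay.

Among these three numbers, compound 2 stands second highest. The closest of the other two is reached by a 3.5-fold lower number from compound 2 to compound 3 (0.54 log units; beyond the scatter), and the furthest by a 6.0-fold lower number from compound 1 to compound 2 (0.78 log units; beyond the scatter).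

Compound 4 `CCNC(=O)Nc1ccc(S(=O)(=O)Oc2ccc(O)cc2)cc1` differs from compound 2 by 4-hydroxyphenyl in place of 2-methylphenyl on an oxygen. Neither measured step matches this change. The step from compound 1 to compound 2 alters the urea chain, far from the sulfonate oxygen. The step from compound 2 to compound 3 does touch the ring on that oxygen, but only by lengthening an alkyl group there; the new compound instead removes the alkyl group entirely and brings in a hydroxyl at a different ring position. Among the measured compounds shown here, with no measured step bearing on it, the direction is open. As far as these compounds go, the lengthened alkyl lowered the number, so removing it might be expected to raise it, while the hydroxyl is untested. Compound 4 is therefore expected to give 7000 nM, within 1800 nM to 27000 nM, meaning an expected 1.6-fold higher number from compound 2 to compound 4 (0.19 log units; within the scatter) that may not clear the scatter.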

Compound 4, half-maximal inhibitory concentration: 8000 nM
The estimate for compound 4 lay 1.1-fold (0.06 log units) below the measured number, within the range that was stated.
By their numbers in this assay, from the lowest: compound 3; then compounds 2 and 4 (each within the scatter of the next); then compound 1.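

In this assay, placing 4-hydroxyphenyl instead of 2-methylphenyl on the oxygen bound to the sulfonyl sulfur gives a 1.8-fold higher number from compound 2 to compound 4 (0.25 log units; within the scatter) and so does not separate the two compounds. Among the compounds shown here, the earlier compounds had probed this ring only by lengthening an alkyl group, in a 3.5-fold lower number from compound 2 to compound 3 (0.54 log units; beyond the scatter) as the one step there; this result adds that a group with a different atom makeup, bringing 1 hydrogen-bond donor and 1 hydrogen-bond acceptor where 2-methylphenyl has none, can stand on this oxygen with the number staying within the scatter of compound 2. No measurement is available that would explain this result.

As far as these compounds go, the exchange removes the methyl and brings in the hydroxyl in a single step, so what each contributes alone stays unknown, and plain phenyl on the same oxygen would be needed to tell them apart. Also open, from the compounds shown here alone, is how an amine or a carboxylic acid in place of the hydroxyl would read, and whether 4-hydroxyphenyl would give a similar result with the longer chlorinated chain of compound 1 on the urea.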